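This account rests on a few compounds, and the source may have more. Where it says the series, first, only, none or still open, it means among the compounds named here.

In a functional assay on B16-F10 cells (Mus musculus) for inhibition, read by MTT assay, with a stated time of 72 h (a higher number here means a weaker inhibitor, a lower number a stronger inhibitor), compound 1 (`CC1(C)CC(NC(=S)Nc2cccc(C#N)c2)c2cc(Br)ccc2O1`) gives 7000 nM and compound 2 (`CC1(C)CC(NC(=S)Nc2cccc([N+](=O)[O-])c2)c2cc(Br)ccc2O1`) gives 5000 nM. Among the measured compounds shown here, these two values lie within the scatter of each other, so compound 2 stands level with the only other measured compound. Compound 3 (`CC1(C)CC(NC(=S)Nc2cccc(Cl)c2)c2cc(Br)ccc2O1`) follows from compound 2 by chloro in place of nitro on an aromatic carbon. For the measured compounds named here, the one measured step bearing on this is a 1.4-fold lower number from compound 1 to compound 2 (0.15 log units; within the scatter), where nitro replaces cyano. On that basis, no step beyond the scatter is expected in this assay, and no direction is favoured. Compound 3 is estimated at 4500 nM, with an expected range of 2000 nM to 10000 nM. The expected change is a 1.1-fold lower number from compound 2 to compound 3 (0.05 log units; within the scatter).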

Compound 3, half-maximal inhibitory concentration: 7000 nM
The estimate for compound 3 lay 1.6-fold (0.19 log units) below the measured number; the measured number falls inside the stated range.
By their numbers in this assay, from the lowest: compounds 2, 1 and 3 (each within the scatter of the next).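

On an aromatic carbon meta to a large group, chloro now stands with nitro and cyano, and in this assay the steps read (a 1.4-fold higher number from compound 2 to compound 3 (0.15 log units; within the scatter)) and (no change at the digits printed from compound 1 to compound 3 (within the scatter)). Replacing the three heavy atoms of nitro with the single chlorine therefore gives no step beyond the scatter, and these three groups cannot be told apart at this place. No supporting data bear on this result.

As far as these compounds go, whether an amine or a carboxylic acid at this place would give a step beyond the scatter remains open.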